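Methyl step on the compound 3 scaffold

A few compounds are considered here, and "the series" means these few. Any claim that something is new, unique, unknown or untested is made for them only; others in the source may bear on it.

- compound 1 `O=c1ccn([C@H]2C[C@H](Oc3no[n+]([O-])c3S(=O)(=O)c3ccccc3)[C@@H](CO)O2)c(=O)[nH]1`: 2900 nM
- compound 2 `Cc1cn([C@H]2C[C@H](Oc3no[n+]([O-])c3S(=O)(=O)c3ccccc3)[C@@H](CO)O2)c(=O)[nH]c1=O`: 880 nM
- compound 3 `O=c1ccn([C@H]2C[C@H](O)[C@@H](COc3no[n+]([O-])c3S(=O)(=O)c3ccccc3)O2)c(=O)[nH]1`: 6300 nM

All three values come from a functional assay on 143B cells (Homo sapiens) for cytotoxicity; on this read-out lower numbers stand for higher toxicity in this test and higher numbers for lower toxicity in this test. On this read-out, compound 3 has the highest number of the three at 6300 nM, compared with compound 1 at 2900 nM and compound 2 at 880 nM.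

Compound 4 `Cc1cn([C@H]2C[C@H](O)[C@@H](COc3no[n+]([O-])c3S(=O)(=O)c3ccccc3)O2)c(=O)[nH]c1=O` is still unmeasured. It departs from compound 3 by one change: methyl in place of hydrogen on an aromatic carbon. This is methyl in place of hydrogen on an aromatic carbon, on a six-membered aromatic ring with 2 nitrogen.

Among the compounds with values here, only one measured step bears on this change, namely a 3.3-fold lower number from compound 1 to compound 2 (0.52 log units; beyond the scatter). It is the same replacement, and it is modest but beyond the scatter. However, the large group in compound 1 and compound 2 is attached at a different place from the one in compound 3, and there is no second pair to show whether the step carries over. A modest step towards a lower number is therefore expected in this assay, with wide margins.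

The estimated step is a 3.2-fold lower number from compound 3 to compound 4 (0.50 log units; beyond the scatter).

For compound 4 the expected value is 2000 nM, with an estimated range of 850 nM to 4800 nM.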

Compound 4, half-maximal cytotoxic concentration: 5600 nM
Compound 4: middle estimate off by 2.8-fold (0.45 log units), on the low side; measured number above the stated range.
By their numbers in this assay, from the lowest: compound 2; then compounds 1, 4 and 3 (each within the scatter of the next, the first and the last beyond it).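

Within the data shown here, on the core of compound 3, methyl in place of hydrogen on an aromatic carbon gives no step that can be told from the scatter in this assay: the measured change is a 1.1-fold lower number from compound 3 to compound 4 (0.05 log units; within the scatter). The earlier pair alone could not show whether the methyl step carried over to the other attachment of the large group, and the two cores now give clearly different results for the same replacement: the same change on two cores in this assay, a 3.3-fold lower number (0.52 log units; beyond the scatter) from compound 1 to compound 2 and a 1.1-fold lower number (0.05 log units; within the scatter) from compound 3 to compound 4, 2.9-fold (0.47 log units) apart, beyond the scatter of two such steps. In this assay, the step seen on the core of compound 1 therefore cannot be treated as a general property of this position across the two cores.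

On these data alone, whether an ethyl group, a longer chain or a bromine at this position would give a step beyond the scatter on the core of compound 3, and how that step would compare with one on the core of compound 1, remains open. As far as these compounds go, with a single pair on each core, it also remains open whether the place of attachment of the large group alone sets the difference between the two steps.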